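The compounds below may be only part of what the source reports. "The series", "measured", "known", "first", "only" and "open" are said of these compounds alone.

Compound 1 `O=C(/C=C/c1ccc2c(c1)B(O)OC2)c1cccs1` carries a thiophen-2-yl group on the carbonyl carbon, and in a toxicity assay on MCF-10A cells (Homo sapiens) for cytotoxicity, read by MTT assay, with a stated time of 48 h (on this read-out higher numbers stand for weaker inhibition and lower numbers for stronger inhibition), compound 1 gives 13800 nM. Compound 2 `Cn1cccc1C(=O)/C=C/c1ccc2c(c1)B(O)OC2` has 1-methyl-1H-pyrrol-2-yl in place of thiophen-2-yl on that carbon. For compound 2 the this assay result is a limit of the assay, > 100000 nM. Compound 3 `O=C(/C=C/c1ccc2c(c1)B(O)OC2)c1ccc(I)cc1` has 4-iodophenyl in place of thiophen-2-yl on the carbonyl carbon. For compound 3 as well the this assay result is a limit, > 100000 nM. Compound 3 thus stands at the limit of > 100000 nM in this assay, at which 2 of the 3 values shown sit, the weak end of everything measured here. Both an at least 7.2-fold higher number from compound 1 to compound 2 (0.86 log units; beyond the scatter) and an at least 7.2-fold higher number from compound 1 to compound 3 (0.86 log units; beyond the scatter) run upward, toward weaker inhibition, while a step that the two limits leave unreadable from compound 2 to compound 3.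

Compound 4 `CCOC(=O)c1ccc(C(=O)/C=C/c2ccc3c(c2)B(O)OC3)cc1` differs from compound 3 by ethoxycarbonyl in place of iodo on an aromatic carbon. For the measured compounds named here, no measured step alters a group on the six-membered aromatic ring of carbon only; the two readable steps both concern the group on the carbonyl carbon, and they are of little direct help for this change. With compound 3 at the limit, the step of a number no higher from compound 3 to compound 4 (the limit leaves the size open) is expected to be small, most probably leaving compound 4 at the same limit. Compound 4 is therefore estimated at 100000 nM in this assay, with a range from 30000 nM to 300000 nM.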

Compound 4, half-maximal inhibitory concentration: 12900 nM
For compound 4 the middle estimate is 7.8-fold (0.89 log units) above the measured one; measured number below the stated range.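

For the compounds shown here, replacing iodo with ethoxycarbonyl gives an at least 7.7-fold lower number from compound 3 to compound 4 (0.88 log units; beyond the scatter), the first readable step on an aromatic carbon of the six-membered aromatic ring of carbon only, para to a large group, and it runs toward stronger inhibition. The earlier steps shown here had changed only the whole group on the carbonyl carbon, whereas this one shows that a single substituent on that ring can move a compound off the limit in this assay, with the rest of the structure unchanged. Compound 3 itself reads only as a limit of the assay, so the step sets a minimum size and not an exact one: the limit of > 100000 nM in this assay, at which 2 of the 4 values shown sit.

The compounds shown leave open whether this reading belongs to the ethoxycarbonyl group in particular, or whether a carboxylic acid, an amide, an amine or a plain hydrogen at the same place would also read below the limit. They also leave open whether a longer ester chain would shift the number further, and nothing here shows how far the same substituent would carry over to a different group on the carbonyl carbon.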